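This account rests on a few compounds, and the source may have more. Where it says the series, first, only, none or still open, it means among the compounds named here.

For the measured compounds named here, in a functional assay on A549 cells (Homo sapiens) for inhibition, read by sulforhodamine B assay, with a stated time of 48 h (a lower number here means a stronger inhibitor, a higher number a weaker inhibitor), compound 2 `COc1ccc(C(OCc2ccc(C)cc2)c2cccc3ccccc23)c(OC)c1OC` gives 15700 nM, one of only two numbers in hand and within the scatter of the other. Going by the values given here, compound 1 `COc1ccc(C(OCc2ccccc2)c2cccc3ccccc23)c(OC)c1OC` gives 13500 nM, and the step of a 1.2-fold higher number from compound 1 to compound 2 (0.07 log units; within the scatter) is the only measured change so far. Compound 3 `COC(=O)c1ccc(COC(c2ccc(OC)c(OC)c2OC)c2cccc3ccccc23)cc1` differs from compound 2 by methoxycarbonyl in place of methyl on an aromatic carbon. The earlier step changed the same aromatic carbon with a smaller group and stayed within the scatter, so nothing beyond the scatter is foreseen here: the expected step is a 1.0-fold lower number from compound 2 to compound 3 (0.02 log units; within the scatter). Compound 3 is therefore estimated at 15000 nM, within a range from 5000 nM to 45000 nM.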

Compound 3, half-maximal inhibitory concentration: 12000 nM
Beside the measured number, compound 3's estimate is 1.3-fold (0.10 log units) above it; the measured number falls inside the stated range.
By their numbers in this assay, from the lowest: compounds 3, 1 and 2 (each within the scatter of the next).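

Swapping 4-methylbenzyl for 4-(methoxycarbonyl)benzyl brings in a larger group carrying hydrogen-bond acceptors, yet in this assay it gives a 1.3-fold lower number from compound 2 to compound 3 (0.12 log units; within the scatter) and no change beyond the scatter. Placing the same group where compound 1 has hydrogen gives a 1.1-fold lower number from compound 1 to compound 3 (0.05 log units; within the scatter) and likewise stays within the scatter, so hydrogen, methyl and methoxycarbonyl all read alike at this position. No measurement at hand explains this. On these data alone, whether an amine or a carboxylic acid at this position would move the number beyond the scatter remains open, as do changes elsewhere on the shared core.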